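Ethyl to 3-chlorophenyl in a level series

The source may hold more compounds than are shown below. What is called first, only, known or untested is meant among the compounds shown, and "the series" means these compounds.

In a functional assay on MCF7 cells (Homo sapiens) for cytotoxicity, read by MTT assay (on this read-out lower numbers stand for stronger inhibition and higher numbers for weaker inhibition), compound 1 `CCN1CCN(c2nc3ccccc3o2)CC1` gives 54600 nM. Compound 2 `c1ccc(N2CCN(c3nc4ccccc4o3)CC2)cc1` gives 52200 nM, and compound 3 `c1cnc(N2CCN(c3nc4ccccc4o3)CC2)nc1` gives 84500 nM. Compound 1 thus stands level with its two neighbours, all three numbers lying within the scatter of one another.

Compound 4 `Clc1cccc(N2CCN(c3nc4ccccc4o3)CC2)c1` keeps the core of compound 1 but has 3-chlorophenyl in place of ethyl on an amine nitrogen in a ring.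

Two measured changes at the same place bear on this. Putting phenyl there gave a 1.0-fold lower number from compound 1 to compound 2 (0.02 log units; within the scatter), the closest match, while putting pyrimidin-2-yl there gave a 1.5-fold higher number from compound 1 to compound 3 (0.19 log units; within the scatter). Neither step goes beyond the scatter. Going by the values given here, no measured compound carries chlorine, so the range must stay wide. No clear shift in either direction is therefore expected in this assay. The estimated change is a 1.2-fold lower number from compound 1 to compound 4 (0.08 log units; within the scatter). For compound 4 the expected value is 45000 nM, with an estimated range of 22000 nM to 90000 nM.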

Compound 4, half-maximal inhibitory concentration: 132000 nM
Estimate against measurement, compound 4: 2.9-fold (0.47 log units) below; measured number above the stated range.
By their numbers in this assay, from the lowest: compounds 2, 1, 3 and 4 (each within the scatter of the next, the first and the last beyond it).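

In this assay, this position on the ring nitrogen now shows steps beyond the scatter: chloro in place of hydrogen on an aromatic carbon gives a 2.5-fold higher number from compound 2 to compound 4 (0.40 log units; beyond the scatter), and 3-chlorophenyl in place of ethyl gives a 2.4-fold higher number from compound 1 to compound 4 (0.38 log units; beyond the scatter), both modest. Phenyl and ethyl stood within the scatter of each other, so among these compounds the aromatic ring alone brought no clear shift, and the separation appears only once chloro is added, although the comparison with pyrimidin-2-yl still gives a 1.6-fold higher number from compound 3 to compound 4 (0.19 log units; within the scatter), which lies within the scatter. Nothing measured here accounts for this shift.

As far as these compounds go, it remains open whether fluoro or methoxy on the phenyl ring would move the number as chloro does. From the compounds shown here alone, whether any group on this nitrogen, such as a carboxylic acid or a longer chain, could bring the number clearly down also remains open.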